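The source may report more compounds than this note shows. Statements on the series, on what has been measured and on what is new or still open speak of the compounds shown alone.

Measured compounds:
compound 1 `COc1cc(OC)c(OC)cc1/C=C/C(=O)c1ccc(OC)c2c1OC(C)(C)C=C2` gave > 10000 nM
compound 2 `COc1ccc(C(=O)/C=C/c2cccc(F)c2)c2c1C=CC(C)(C)O2` gave > 10000 nM
compound 3 `COc1ccc(C(=O)/C=C/c2ccc3ccccc3c2)c2c1C=CC(C)(C)O2` gave 2140 nM

Three compounds sharing one core were tested in a functional assay on SW-620 cells (Homo sapiens) for antiproliferative activity, read by MTT assay, with a stated time of 24 h; a higher number here means a weaker inhibitor, a lower number a stronger inhibitor. Compound 1 gave > 10000 nM, which is a limit of the assay and not a number. Compound 2 likewise gave > 10000 nM, again a limit. For the measured compounds named here, compound 3 gave 2140 nM, the only measured number among the three. Compound 2 therefore stands at the limit of > 10000 nM in this assay, at which 2 of the 3 values shown sit, with no number of its own.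

Compound 4 `COc1ccc(C(=O)/C=C/c2ccc([N+](=O)[O-])cc2)c2c1C=CC(C)(C)O2` is not yet measured. It differs from compound 2 in one place: 4-nitrophenyl in place of 3-fluorophenyl on a double-bonded chain carbon bound to a double-bonded chain carbon. Going by the values given here, no pair of measured compounds differs in just this way, so the step from compound 2 to compound 4 has no direct precedent. Among the compounds with values here, since compound 2 sits at a limit, only a move to a number well under that limit could be seen at all, and nothing among the measured compounds points firmly either way. The expected step is an at least 1.1-fold lower number from compound 2 to compound 4 (0.04 log units; that floor lies within the scatter), within the scatter. Compound 4 is expected at about 9000 nM, with a range from 2500 nM to 30000 nM, most likely reported again as a limit.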

Compound 4, half-maximal inhibitory concentration: 3520 nM
Compound 4: middle estimate off by 2.6-fold (0.41 log units), on the high side; the measured number falls inside the stated range.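

In this assay, for the compounds shown here, the earlier compounds gave no step at this double-bonded chain carbon, but 4-nitrophenyl in place of 3-fluorophenyl now gives an at least 2.8-fold lower number from compound 2 to compound 4 (0.45 log units; beyond the scatter). The aromatic group at this place can therefore decide whether a compound gives a measured number or stays at the limit, at least for this pair. The true size of the step remains unknown, and the printed size is only a floor because compound 2 has a limit and not a number of its own: the limit of > 10000 nM in this assay, at which 2 of the 4 values shown sit.

Two things change together in this step, the group on the phenyl ring and where it sits on that ring, and the compounds shown do not separate them. Also open, from the compounds shown here alone, is how an amine or a carboxylic acid in place of the nitro group would read at this place.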